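Cycloheptyl amides of an indole butanoic acid: Vero cytotoxicity

The compounds below may be only part of what the source reports. "The series", "measured", "known", "first", "only" and "open" are said of these compounds alone.

Three members of the series have been run in an ADME assay on Vero cells (Chlorocebus sabaeus) for cytotoxicity, read by fluorescence and resazurin assay, with a stated time of 3 days; on this read-out higher numbers stand for lower toxicity in this test and lower numbers for higher toxicity in this test. For compound 1 `O=C(CCCc1cn(Cc2ccc(Br)cc2)c2ccccc12)NC1CCCCCC1` the outcome is recorded as "not determined" (no result reported), and for compound 2 `C=CCn1cc(CCCC(=O)NC2CCCCCC2)c2ccccc21` likewise as "not determined" (no result reported); neither carries a number. Compound 3 `Cc1ccc(S(=O)(=O)n2cc(CCCC(=O)NC3CCCCCC3)c3ccccc32)cc1` gives > 250000 nM in this assay, which is a limit of the test rather than a measured value. Within the three entries shown, compound 3 therefore stands at the limit of > 250000 nM in this assay, at which 1 of the 3 values shown sits, the only quantitative anchor, and no pairwise step between measured compounds can be stated.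

Compound 4 `O=C(CCCc1cn(S(=O)(=O)c2cccc3ccccc23)c2ccccc12)NC1CCCCCC1` has not yet been measured in this assay. Relative to compound 3 the change is naphthalen-1-yl in place of 4-methylphenyl on a sulfonyl sulfur. Among the compounds with values here, no measured step exists on which to scale the effect of this change, so the expectation rests on compound 3 alone. The step from compound 3 to compound 4 in this assay is expected to be small, an at least 1.2-fold lower number from compound 3 to compound 4 (0.09 log units; that floor lies within the scatter), and not to move the compound clearly beyond the scatter. Compound 4 is accordingly estimated at 200000 nM, with a likely range from 70000 nM to 300000 nM, and a fair chance that this assay again returns only a limit rather than a number.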

Compound 4, half-maximal cytotoxic concentration: > 250000 nM
Compound 4 was reported as a limit (the forecaster's own chance of this, stated with the estimate: 55%); middle value at least 1.2-fold (0.09 log units) from the limit.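

Compound 3 and compound 4 each return only a limit in this assay, so no step can be read for naphthalen-1-yl in place of 4-methylphenyl on a sulfonyl sulfur: the limit of > 250000 nM in this assay, at which 2 of the 4 values shown sit. The compounds shown leave open whether this change affects the half-maximal cytotoxic concentration, and at what concentration either compound would reach it.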